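A few compounds are considered here, and "the series" means these few. Any claim that something is new, unique, unknown or untested is made for them only; others in the source may bear on it.

Working notes on the series.

Compound 1 `CS(=O)(=O)c1cc(F)ccc1NCC1=NCCN1` and compound 2 `CSc1cc(F)ccc1NCC1=NCCN1` share one core; compound 3 `CS(=O)(=O)c1ccc(Cl)cc1NCC1=NCCN1` and the not yet measured compound 4 `CSc1ccc(Cl)cc1NCC1=NCCN1` share another. The difference between the two cores is not broken down here. In a functional assay for agonist activity at Alpha-1B adrenergic receptor (Homo sapiens) (on this read-out lower numbers stand for an effect already at smaller amounts and higher numbers for an effect only at larger amounts of compound), compound 1 gives only a limit, < 100000 nM, not a number. Compound 2 gives 6.03 nM, and compound 3 gives 61.7 nM, the highest number among the two read values.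

The change from compound 1 to compound 2 is methylsulfanyl in place of methylsulfonyl on an aromatic carbon. The step that the limit leaves unreadable from compound 1 to compound 2 cannot be sized because compound 1 sits at the limit (the limit of < 100000 nM in this assay, at which 1 of the 3 values shown sits). The same kind of change is made from compound 3 to compound 4: methylsulfanyl in place of methylsulfonyl on an aromatic carbon. What differs around the place is that in compound 1 the position is meta to a fluoro group, in compound 3 para to a chloro group, so the two changes are alike in kind, not the same.

From compound 3 to compound 4 a step of a 6.2-fold lower number from compound 3 to compound 4 (0.79 log units; beyond the scatter) is expected, resting on compound 2 at 6.03 nM as the only measured thioether, with the first step unreadable. Compound 4 is estimated at 10 nM in this assay, between 2 nM and 50 nM.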

Compound 4, half-maximal effective concentration: 0.501 nM
For compound 4 the middle estimate is 20-fold (1.30 log units) above the measured one; measured number below the stated range.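

In this assay, methylsulfanyl in place of methylsulfonyl on an aromatic carbon gives a 120-fold lower number from compound 3 to compound 4 (2.09 log units; beyond the scatter), so in the core of compound 3 this change has a large effect on the read-out. This is one readable pair, and it shows nothing about why the number falls, since no measured property of either group is given here. Whether the change carries from one core to the other in size, or even in direction, stays unsettled: the matching step in the core of compound 1 cannot be read, and the two steps cannot be compared: the limit of < 100000 nM in this assay, at which 1 of the 4 values shown sits.

Open is how a methoxy group, an ethylsulfanyl chain or an amine on the same aromatic carbon would read in this assay, since methylsulfanyl and methylsulfonyl are the only two groups shown there. Also open, from the compounds shown here alone, is whether a step of this size would recur in a core carrying a bromo group or a methyl group in place of the chloro group.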